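This account rests on a few compounds, and the source may have more. Where it says the series, first, only, none or still open, it means among the compounds named here.

Two compounds of this series carry numbers in a functional assay on the whole organism (strain albino) for inhibition, with Rattus norvegicus as the target, read by paw edema, with stated times of 30 min and 3 h, at a dose of 100 mg/kg by the oral route; on this read-out lower numbers stand for less inhibition and higher numbers for more inhibition at the one dose given (going by the name of the read-out). Compound 1 `COc1ccc(C2=NNC(c3c(Cl)cccc3Cl)C2)cc1` gives 60% in this assay. Compound 2 `COc1ccc(C2CC(c3ccc(OC)c(OC)c3)=NN2C(=O)CBr)c(OC)c1` gives 71% in this assay and so stands highest of the two numbers, with compound 1 the nearer one, a number lower by a margin beyond the scatter. For the measured compounds named here, no pair of measured compounds differs in only one place, so no single-change step is on record.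

Compound 3 `COc1ccc(C2CC(c3ccc(OC)c(OC)c3)=NN2C(=O)C(C)O[N+](=O)[O-])c(OC)c1` is the next compound to be measured in this assay. It differs from compound 2 in one place: 1-(nitrooxy)ethyl in place of bromomethyl on a carbonyl carbon. Without a measured step of this kind in the series, the size of the change cannot be read from any neighbour. The step from compound 2 to compound 3 is expected to be a number 1 percentage points higher from compound 2 to compound 3 (within the scatter), that is, none beyond the scatter. Compound 3 is therefore estimated at 72% in this assay, with a range from 58% to 85%.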

Compound 3, a percentage reported as inhibition, in the whole organism at one dose (the size of the read-out at that dose, not a potency): 56%
Compound 3: the middle estimate sits 16 percentage points above what was measured; the whole stated range lies above it.
By their numbers in this assay, from the lowest: compounds 3 and 1 (each within the scatter of the next); then compound 2.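

Working notes: in this assay, 1-(nitrooxy)ethyl in place of bromomethyl on a carbonyl carbon whose other neighbour is an amide-type nitrogen in a ring gives a number 15 percentage points lower from compound 2 to compound 3 (beyond the scatter). For the compounds shown here, this is the first single-change step, and it shows that the number at this dose responds to the group on this carbonyl carbon, with the rest of compound 2 held constant. No measurement on record bears on the reason for this step.

A single exchange cannot separate the loss of bromomethyl from the entry of 1-(nitrooxy)ethyl, so the contribution of each remains unassigned. Still open, on these data alone, is how this read-out would respond to 1-hydroxyethyl, which keeps the branched carbon without the nitrate ester, or to unbranched nitrooxymethyl on the same carbonyl carbon.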